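A few compounds are considered here, and "the series" means these few. Any claim that something is new, unique, unknown or untested is made for them only; others in the source may bear on it.

Compound 1 `NC(=S)/N=C1/CC[C@H]2CO[C@@H]1O2` is the parent of this small series. In a functional assay on HeLa cells (Homo sapiens) for cytotoxicity, read by CCK-8 assay, with a stated time of 72 h (on this read-out higher numbers stand for weaker inhibition and lower numbers for stronger inhibition), compound 1 reaches only the assay limit, > 1000000 nM. Compound 2 `CC(=O)O[C@@H]1[C@@H](OC(C)=O)[C@H](S[C@@H]2C/C(=N/C(N)=S)[C@@H]3OC[C@H]2O3)OC[C@@H]1OC(C)=O` carries a triacetylated thio-sugar and gives 880000 nM, while compound 3 `CC(=O)OC[C@H]1O[C@@H](S[C@@H]2C/C(=N/C(N)=S)[C@@H]3OC[C@H]2O3)[C@H](OC(C)=O)[C@@H](OC(C)=O)[C@H]1OC(C)=O` carries a tetraacetylated one and gives 602000 nM; the step of a 1.5-fold lower number from compound 2 to compound 3 (0.16 log units; within the scatter) puts compound 3 alongside compound 2 rather than apart from it. Compound 4 `CC(=O)OC[C@H]1O[C@@H](S[C@@H]2C/C(=N/C(N)=S)[C@@H]3OC[C@H]2O3)[C@H](OC(C)=O)[C@@H](OC(C)=O)[C@@H]1OC(C)=O` differs from compound 3 only in that (the two compounds have the same atoms and bonds and differ only in configuration as drawn: 1 of 9 stereo elements differ; a stereocentre at a saturated ring carbon is drawn S in compound 3 and R in compound 4). Among the measured compounds shown here, no measured step in this set touches a configuration change, and the single step that exists, a 1.5-fold lower number from compound 2 to compound 3 (0.16 log units; within the scatter), was itself within the scatter. A step of about a 1.1-fold higher number from compound 3 to compound 4 (0.03 log units; within the scatter) is therefore expected, in no particular direction. Compound 4 is accordingly estimated at 650000 nM, in the range 300000 nM to 1400000 nM.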

Compound 4, half-maximal inhibitory concentration: > 1000000 nM
Compound 4: a limit, no number (the forecaster's own chance of this, stated with the estimate: 30%); middle value at least 1.5-fold (0.18 log units) from the limit.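

Among the compounds shown here, changing a stereocentre at a saturated ring carbon from S to R is the first change here that alters configuration alone, and in this assay it gives an at least 1.6-fold higher number from compound 3 to compound 4 (0.22 log units; that floor lies within the scatter). Compound 4 gives a limit of the assay and not a number, and this leaves the true size of the step unknown. The reading of this pair is therefore bounded: the limit of > 1000000 nM in this assay, at which 2 of the 4 values shown sit.

From the compounds shown here alone, it remains open whether this configuration matters in the triacetylated thio-sugar of compound 2. Going by these compounds, it also remains open whether free hydroxyl groups in place of the acetyl groups would bring a value clear of that limit.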